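The source may report more compounds than this note shows. Statements on the series, on what has been measured and on what is new or still open speak of the compounds shown alone.

Compound 1 `COc1ccc([C@H]2CC(=O)N(c3cccc(N)c3C)C2)cc1OC1CCCC1` and compound 2 `COc1ccc([C@H]2CC(=O)N(c3ccc(C#N)cc3)C2)cc1OC1CCCC1` share one core and differ only at the amide-type nitrogen in a ring. In a functional assay on HEK293 cells (Homo sapiens) for cytotoxicity (on this read-out lower numbers stand for higher toxicity in this test and higher numbers for lower toxicity in this test), compound 1 gives only a limit, > 10000 nM. Compound 2 also gives only a limit in this assay, > 10000 nM. The step that the two limits leave unreadable from compound 1 to compound 2 therefore stays unreadable. Compound 3 `COc1ccc([C@H]2CC(=O)N(c3cccc(S(C)(=O)=O)c3)C2)cc1OC1CCCC1` carries 3-(methylsulfonyl)phenyl in place of 4-cyanophenyl on an amide-type nitrogen in a ring. Both measured values sit at the same limit (the limit of > 10000 nM in this assay, at which 2 of the 2 values shown sit), so no shift beyond the scatter is expected. Compound 3 is estimated to give 15000 nM, within 7000 nM to 40000 nM. The expected step that the limit leaves unreadable from compound 2 to compound 3 is accordingly none beyond the scatter.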

Compound 3, half-maximal cytotoxic concentration: > 10000 nM
Compound 3: a limit, no number; the forecaster's own chance of this, stated with the estimate: 80%; the middle value does not contradict the limit.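

In this assay compound 3 gives > 10000 nM, which is a limit. No step among compound 1, compound 2 and compound 3 can therefore be read: the limit of > 10000 nM in this assay, at which 3 of the 3 values shown sit.

The compounds shown leave open whether the group on the amide-type nitrogen in a ring changes the half-maximal cytotoxic concentration.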